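Removing a Fluorine From a Furan-Linked Amidine

The source may report more compounds than this note shows. Statements on the series, on what has been measured and on what is new or still open speak of the compounds shown alone.

The compounds here were tested in a functional assay on K562 cells (Homo sapiens) for inhibition, read by sulforhodamine B assay, with a stated time of 48 h; on this read-out higher numbers stand for weaker inhibition of growth and lower numbers for stronger inhibition of growth. Compound 1, whose structure is `N=C(N)c1ccc(-c2ccc(-c3ccc(F)cc3)o2)o1`, gives 490 nM in this assay. Among the three compounds measured so far, compound 1 stands at the lowest number, with both of the others beyond the usual scatter. The nearest is compound 3, `N=C(N)c1ccc(-c2ccc(-c3ccc(F)cc3)s2)s1`, which replaces the two oxygen-containing rings of the shared core with sulfur-containing ones and gives 1210 nM in this assay. The furthest is compound 2, `N=C(N)c1ccc(-c2ccc(-c3cc(Cl)cc(Cl)c3)o2)o1`, which carries two chloro groups instead of the single fluoro and gives 1300 nM in this assay.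

Compound 4, `N=C(N)c1ccc(-c2ccc(-c3ccccc3)o2)o1`, has not yet been measured. Compared with compound 1 the change is hydrogen in place of fluoro on an aromatic carbon. Among the compounds with values here, no pair of measured compounds differs by this change alone, so there is no measured step to lean on. A single fluorine on an aromatic ring is a small part of the whole molecule, and the expectation is for a step of modest size, most likely within the usual scatter, if anything toward a slightly higher number. The step from compound 1 to compound 4 is therefore estimated at a 1.4-fold higher number from compound 1 to compound 4 (0.15 log units; within the scatter) in this assay. On that basis compound 4 is expected to give about 700 nM in this assay, within a range of 300 nM to 1600 nM.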

Compound 4, concentration for 50% growth inhibition: 660 nM
For compound 4 the middle estimate is 1.1-fold (0.03 log units) above the measured one; measured number inside the range.
By their numbers in this assay, from the lowest: compounds 1, 4, 3 and 2 (each within the scatter of the next, the first and the last beyond it).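

Swapping the fluoro on the aromatic carbon, para to a large group, for a plain hydrogen gives a 1.3-fold higher number from compound 1 to compound 4 (0.13 log units; within the scatter) in this assay. Within the data shown here, this is the first direct look at this position, and it shows that compound 1 and compound 4 cannot be told apart here, so in this one pair the fluoro is not needed to keep growth inhibition at this level. Nothing at hand explains this result, and the data offer no measurement of what the fluoro does or does not do to the molecule.

As far as these compounds go, with only fluoro and hydrogen compared at this position, it remains open whether a larger or very different group there, such as a methoxy group, an amine or a carboxylic acid, would produce a step beyond the scatter. From the compounds shown here alone, it is also open whether the same swap of fluoro for hydrogen would give a similarly small step on the sulfur-containing core of compound 3, since this single pair speaks only for the core shared by compound 1 and compound 4.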